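The compounds below may be only part of what the source reports. "The series", "measured", "known", "first", "only" and "open" are said of these compounds alone.

Compound 2 `CC(=O)c1cc2ccc(OCCCCCn3cc(CNC(=O)CCCCC4CCSS4)nn3)cc2oc1=O` gives 20.7% in a functional assay on PC-12 cells (Rattus norvegicus) for cytotoxicity, read by MTT assay, with stated times of 3 h and 2 h, tested at 20 uM (on this read-out higher numbers stand for a stronger effect at the one concentration tested and lower numbers for a weaker effect), the lower of the two numbers in hand. Within the data shown here, compound 1 `COc1ccc(-c2cc3ccc(OCCCCn4cc(CNC(=O)CCCCC5CCSS5)nn4)cc3oc2=O)cc1` gives 52.3% in this assay, beyond the scatter above compound 2, but the two structures differ at more than one place, so no single step is isolated. Compound 3 `O=C(CCCCC1CCSS1)NCc1cn(CCCCCOc2ccc3cc(-c4ccc(Cl)c(Cl)c4)c(=O)oc3c2)nn1` carries 3,4-dichlorophenyl in place of acetyl on an aromatic carbon. Among the measured compounds shown here, an aromatic ring at that position is seen only in compound 1, whose 52.3% is the sole guide, so the expected step of a number 21.3 percentage points higher from compound 2 to compound 3 (beyond the scatter) is a rise of moderate size, held loosely. Compound 3 is therefore estimated at 42%, within 22% to 62%.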

Compound 3, a percentage reported as activity, at one concentration (the size of the read-out at that concentration, not a potency): 65.5%
Estimate against measurement, compound 3: 23.5 percentage points below; the measured number lies above the stated range.
By their numbers in this assay, from the lowest: compound 2; then compound 1; then compound 3.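

At this position, an aromatic carbon two atoms from the ring oxygen, 3,4-dichlorophenyl in place of acetyl gives, in this assay, a number 44.8 percentage points higher from compound 2 to compound 3 (beyond the scatter). Among these compounds, this is the only single-place step in hand, and it shows that the read-out responds strongly to the group carried here. Nothing measured on these compounds accounts for the step.

From the compounds shown here alone, whether the step belongs to the aromatic ring or to its chlorine atoms remains open, and an unsubstituted phenyl would separate the two. Going by these compounds, how an amine or a carboxylic acid at this position would read is also open.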